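Two limits and a nitro replacement

The source may report more compounds than this note shows. Statements on the series, on what has been measured and on what is new or still open speak of the compounds shown alone.

Measured in a physicochemical assay for lipophilicity, at pH 7.4 (a lower number here means a more polar compound, a higher number a more lipophilic compound), both values being limits of the assay and not numbers:
- compound 1 `Cc1cc(CNCCCC[C@@H](Nc2cc(C)c(F)c(C)c2)C(=O)NO)ccc1F`: < 3
- compound 2 `Cc1cc(N[C@H](CCCCNCc2ccc(C(F)(F)F)cc2)C(=O)NO)cc(C)c1F`: < 3

Compound 2 gives < 3 in this assay, and this is a limit, not a number. The next compound, compound 3 `Cc1cc(N[C@H](CCCCNCc2ccc([N+](=O)[O-])cc2)C(=O)NO)cc(C)c1F`, has not yet been measured. It differs from compound 2 by nitro in place of trifluoromethyl on an aromatic carbon.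

Among the measured compounds shown here, only one measured step bears on this change: a step that the two limits leave unreadable from compound 1 to compound 2. That step also concerns the 4-(trifluoromethyl)phenyl group, but it offers no size to carry over. The two measured compounds stand together at the limit of < 3 in this assay, at which 2 of the 2 values shown sit, and the data therefore give no measured direction for the new replacement. The expected step, a step that the limit leaves unreadable from compound 2 to compound 3, is an estimate with no measured size behind it. Compound 3 may well be reported as a limit too. Compound 3 is expected at 2.4, with an estimated range of 1.7 to 3.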

Compound 3, distribution coefficient: < 3
Compound 3: a limit, no number (the forecaster's own chance of this, stated with the estimate: 85%); the middle value is on the limit's open side.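

Compound 3 gives < 3 in this assay, and this is a limit, not a number. No step can be read from compound 2 to compound 3 or from compound 1 to compound 3: the limit of < 3 in this assay, at which 3 of the 3 values shown sit. The compounds shown leave open whether nitro in place of trifluoromethyl changes the distribution coefficient at all, and by how much.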